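This account rests on a few compounds, and the source may have more. Where it says the series, first, only, none or still open, it means among the compounds named here.

Measured so far in an ADME assay on WI-38 cells (Homo sapiens) for cytotoxicity, read by MTT assay, with a stated time of 72 h; a lower number here means a stronger inhibitor, a higher number a weaker inhibitor:

Compound 1, `CN(C)CCn1cnnc1-c1cc(Oc2ccc(NC(=O)Nc3ccc(F)c(F)c3)cc2F)ccn1`: > 50000 nM
Compound 2, `CN(C)CCn1cnnc1-c1cc(Oc2ccc(NC(=O)Nc3ccc(F)c(Cl)c3)cc2F)ccn1`: 7580 nM
Compound 3, `CCN(CC)CCn1cnnc1-c1cc(Oc2ccc(NC(=O)Nc3ccc(F)c(F)c3)cc2F)ccn1`: > 50000 nM

The value of compound 1 in this assay is a limit of the assay, not a number. The value of compound 3 in this assay is likewise a limit. Compound 2 is the only one of the three with a number. Going from compound 1 to compound 2 the change is chloro in place of fluoro on an aromatic carbon, and it gives an at least 6.5-fold lower number from compound 1 to compound 2 (0.81 log units; beyond the scatter); the reading rests on (the limit of > 50000 nM in this assay, at which 2 of the 3 values shown sit). The two cores differ as diethylamino in place of dimethylamino on a saturated chain carbon, two bonds along the chain from an aromatic nitrogen, and that step is a step that the two limits leave unreadable from compound 1 to compound 3, since both values are limits.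

Compound 4, `CCN(CC)CCn1cnnc1-c1cc(Oc2ccc(NC(=O)Nc3ccc(F)c(Cl)c3)cc2F)ccn1`, is not yet measured. It differs from compound 3 by chloro in place of fluoro on an aromatic carbon, the same change that took compound 1 to compound 2, at the same place. The expected step is an at least 4.1-fold lower number from compound 3 to compound 4 (0.61 log units; beyond the scatter), resting on an at least 6.5-fold lower number from compound 1 to compound 2 (0.81 log units; beyond the scatter). Compound 4 is therefore estimated at 12000 nM in this assay, within a range from 4000 nM to 50000 nM.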

Compound 4, half-maximal inhibitory concentration: 28700 nM
The estimate for compound 4 lay 2.4-fold (0.38 log units) below the measured number; the measured number falls inside the stated range.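

Carrying chloro in place of fluoro to the diethylamino compounds in this assay gives an at least 1.7-fold lower number from compound 3 to compound 4 (0.24 log units; that floor lies within the scatter) and so does not contradict the direction seen with the dimethylamino compounds, but a floor of that size does not by itself establish a real change. With chloro present, the two amines can be compared directly, giving a 3.8-fold higher number from compound 2 to compound 4 (0.58 log units; beyond the scatter) for diethylamino in place of dimethylamino, whereas the same comparison with fluoro cannot be read since both values are limits. The value of compound 3 is also a limit and not a number, so the size of the change on this core stays unknown, and it cannot be said whether the change is worth the same on both cores: the same change on two cores in this assay, an at least 6.5-fold lower number (0.81 log units; beyond the scatter) from compound 1 to compound 2 and an at least 1.7-fold lower number (0.24 log units; that floor lies within the scatter) from compound 3 to compound 4; the limit leaves it open whether they differ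

The compounds shown leave open whether bromo or trifluoromethyl in that place would follow the same direction as chloro. They also leave open how a longer chain or a dipropylamino group would compare with the two amines seen here.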